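The compounds below may be only part of what the source reports. "The series", "measured", "known", "first", "only" and "open" are said of these compounds alone.

Compound 1 `CCCCC[Se]c1nc(NCc2ccccc2)c2ccccc2n1` gives 99400 nM in a functional assay on MCF7 cells (Homo sapiens) for cytotoxicity, read by MTT assay, with a stated time of 72 h; a higher number here means that more compound is tolerated, a lower number that less compound is tolerated.
Compound 2 `C[Se]c1nc(NCc2ccccc2)c2ccccc2n1` gives > 100000 nM in this assay, and that is a limit of the assay, not a number.

For the measured compounds named here, compound 1 therefore stands as the only compound with an actual number in this assay; the other value shown is a limit (the limit of > 100000 nM in this assay, at which 1 of the 2 values shown sits). Going by the values given here, the one measured step, a number no lower from compound 1 to compound 2 (the limit leaves the size open), concerns a change on the chain at selenium, and its size cannot be read.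

Compound 3 `CCCCC[Se]c1nc(N)c2ccccc2n1` differs from compound 1 by hydrogen in place of benzyl on a nitrogen on an aromatic ring, which, cut one bond further out, reads benzylamino to amino. Among the compounds with values here, no measured step touches this nitrogen, so nothing here tells how large a change to expect, in either direction. For compound 3 the estimate is 90000 nM, ranging from 35000 nM to 230000 nM. The step this implies, a 1.1-fold lower number from compound 1 to compound 3 (0.04 log units; within the scatter), is an expectation not grounded in any measured step.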

Compound 3, concentration lethal to 50% of the cells: 90400 nM
Compound 3: the middle estimate sits 1.0-fold (0.00 log units) below what was measured; the range from low to high includes it.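

In this assay, for the compounds shown here, the first measured step at this nitrogen on an aromatic ring is a 1.1-fold lower number from compound 1 to compound 3 (0.04 log units; within the scatter). The replacement of benzylamino by amino, which removes the whole benzyl with its six-membered aromatic ring of carbon only, therefore leaves the number within the usual scatter. Among the compounds shown, benzyl is not required on this nitrogen for the number to stay where it is, though this rests on a single pair in a single assay.

On these data alone, whether a different group on this nitrogen, such as an acetyl amide or a longer chain, would shift the number remains open, as does whether amino behaves the same way with another chain at selenium. Compound 2 carries a limit and not a number, so the step at selenium still cannot be read: the limit of > 100000 nM in this assay, at which 1 of the 3 values shown sits.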